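Two hydroxyls and a chloro in a quinoxalinone series

This account rests on a few compounds, and the source may have more. Where it says the series, first, only, none or still open, it means among the compounds named here.

Compound 1 `O=C(O)Cn1c(=O)c(Oc2ccc(O)cc2)nc2ccccc21` is the starting point. In a physicochemical assay, read by spectrophotometry, with a stated time of 240 min, tested at 100 uM (on this read-out higher numbers stand for a stronger effect at the one concentration tested and lower numbers for a weaker effect), compound 1 gives 21.3%. Compound 2 `O=C(O)Cn1c(=O)c(Oc2cc(O)cc(O)c2)nc2ccccc21` differs from it by 3,5-dihydroxyphenyl in place of 4-hydroxyphenyl on an oxygen on an aromatic ring and in this assay compound 2 gives 67.4%, so that a number 46.1 percentage points higher from compound 1 to compound 2 (beyond the scatter). Compound 3 `O=C(O)Cn1c(=O)c(Oc2ccc(O)cc2)nc2ccc(Cl)cc21` carries a different core, differing from compound 1 by chloro in place of hydrogen on an aromatic carbon; in this assay compound 3 gives 84.8%, so that a number 63.5 percentage points higher from compound 1 to compound 3 (beyond the scatter), the highest number of the three.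

Compound 4 `O=C(O)Cn1c(=O)c(Oc2cc(O)cc(O)c2)nc2ccc(Cl)cc21` is not yet measured. It differs from compound 3 by 3,5-dihydroxyphenyl in place of 4-hydroxyphenyl on an oxygen on an aromatic ring, which is the same change as that from compound 1 to compound 2, made on the core of compound 3. That earlier step was large, but compound 3 already gives 84.8% in this assay, and the read-out cannot rise much further, so the step is expected to be smaller: a number 8.2 percentage points higher from compound 3 to compound 4 (within the scatter) is the estimated step. For compound 4 the expected value in this assay is 93%, with a likely range from 80% to 100%.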

Compound 4, a percentage reported as activity, at one concentration (the size of the read-out at that concentration, not a potency): 91.3%
Compound 4: middle estimate off by 1.7 percentage points, on the high side; measured number inside the range.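

On the core of compound 1, placing 3,5-dihydroxyphenyl where 4-hydroxyphenyl stood gave a number 46.1 percentage points higher from compound 1 to compound 2 (beyond the scatter) in this assay, but the same change on the core of compound 3 gave a number 6.5 percentage points higher from compound 3 to compound 4 (within the scatter), so the large step did not carry over to the second core. The chloro still counts among the compounds with 3,5-dihydroxyphenyl, with a number 23.9 percentage points higher from compound 2 to compound 4 (beyond the scatter), yet a single pair read close to the top of a percentage scale does not show that the hydroxyl change has no effect on the chlorinated core. Nothing measured here explains why the two steps differ.

As far as these compounds go, it remains open whether another group in place of the chloro, such as a fluoro or a methoxy, would also reduce the step from the hydroxyl change. From the compounds shown here alone, it is also open whether an amine or a carboxylic acid on the aromatic ring could stand in for the hydroxyls, and whether a lower test concentration would separate compound 3 and compound 4.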